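Aryl piperazine dithiocarbamates: fluorophenyl replacement

A few compounds are considered here, and "the series" means these few. Any claim that something is new, unique, unknown or untested is made for them only; others in the source may bear on it.

Measured so far in a functional assay on A549 cells (Homo sapiens) for antiproliferative activity, read by MTT assay, with a stated time of 72 h; on this read-out lower numbers stand for stronger inhibition and higher numbers for weaker inhibition:
- compound 1, `Nc1nc(N)c2cc(CSC(=S)N3CCN(c4ccc(O)cc4)CC3)ccc2n1`: 4210 nM
- compound 2, `Cc1ccc(N2CCN(C(=S)SCc3ccc4nc(N)nc(N)c4c3)CC2)cc1`: 2190 nM

Compound 2 has one neighbour on this read-out, compound 1, and the single measured step of a 1.9-fold lower number from compound 1 to compound 2 (0.28 log units; within the scatter) separates the two; on the numbers shown, compound 2 is not distinguished from compound 1 beyond the scatter.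

Compound 3, `Nc1nc(N)c2cc(CSC(=S)N3CCN(c4ccccc4F)CC3)ccc2n1`, is still to be measured. The change is 2-fluorophenyl in place of 4-methylphenyl on an amine nitrogen in a ring. Within the data shown here, the only step that bears on it is the one from compound 1 to compound 2, in which a group on the aromatic carbon of the same aryl ring was exchanged and the number moved by a 1.9-fold lower number from compound 1 to compound 2 (0.28 log units; within the scatter). That step gives no ground to expect a movement beyond the scatter in this assay for a further exchange of the aryl group, in either direction.

For compound 3 the estimated value is therefore 2600 nM, with a range of 1200 nM to 5800 nM; the expected step is a 1.2-fold higher number from compound 2 to compound 3 (0.07 log units; within the scatter).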

Compound 3, half-maximal inhibitory concentration: 6460 nM
Beside the measured number, compound 3's estimate is 2.5-fold (0.40 log units) below it, outside the stated range (above it).
By their numbers in this assay, from the lowest: compounds 2, 1 and 3 (each within the scatter of the next, the first and the last beyond it).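

In this assay, among these compounds, the aryl group on the amine nitrogen in the ring now gives a first step beyond the scatter: 2-fluorophenyl in place of 4-methylphenyl gives a 2.9-fold higher number from compound 2 to compound 3 (0.47 log units; beyond the scatter), so this position does respond to an exchange of one aryl group for another. Set against 4-hydroxyphenyl, the same 2-fluorophenyl gives a 1.5-fold higher number from compound 1 to compound 3 (0.19 log units; within the scatter), which leaves compound 1 within the scatter of both compound 2 and compound 3, with only that last pair separated. Nothing measured here bears on the reason for this result.

The exchange alters both the substituent and where it sits on the aryl ring, and the compounds shown cannot separate those two changes. From the compounds shown here alone, how an unsubstituted phenyl or an aminophenyl group would read at this position remains open.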